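The source may hold more compounds than are shown below. What is called first, only, known or untested is meant among the compounds shown, and "the series" means these compounds.

Measured compounds:
- compound 1, `O=C(COc1ccc(C(=O)/C=C/c2cccc(Cl)c2)cc1)N[C@H]1CCOC1=O`: in a functional assay on DU-145 cells (Homo sapiens) for antiproliferative activity, read by MTT assay, with a stated time of 72 h (a lower number here means a stronger inhibitor, a higher number a weaker inhibitor), compound 1 gives 3700 nM
- compound 2, `O=C(COc1ccc(C(=O)/C=C/c2ccc(Cl)cc2Cl)cc1)N[C@H]1CCOC1=O`: in this assay compound 2 gives 8610 nM
- compound 3, `O=C1OCC[C@@H]1NC(=S)SCCOc1ccc([N+](=O)[O-])cc1`: in this assay compound 3 gives 31000 nM

Compound 1 gives the lowest number of the three in this assay; its nearest neighbour is compound 2, and compound 3, built on a different core, gives the highest number of the set.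

The unmeasured compound 4, `O=C(COc1ccc(C(=O)/C=C/c2ccc(F)c(F)c2)cc1)N[C@H]1CCOC1=O`, keeps the core of compound 1 and differs from it only in the aryl group on the enone chain: 3,4-difluorophenyl in place of 3-chlorophenyl on a double-bonded chain carbon bound to a double-bonded chain carbon.

Among the compounds with values here, the one measured step on the same position is a 2.3-fold higher number from compound 1 to compound 2 (0.37 log units; beyond the scatter), a change of halogen pattern that nudged the number upward only modestly. Within the data shown here, no measured pair swaps chlorine for fluorine or places two fluorines on that ring, so the direction for compound 4 rests on that single step alone. The expectation is therefore a small step, at most of the same size as the step from compound 1 to compound 2 and possibly within the scatter, as a 1.4-fold higher number from compound 1 to compound 4 (0.13 log units; within the scatter).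

Compound 4 is expected to give about 5000 nM in this assay, in a range from 2000 nM to 13000 nM.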

Compound 4, half-maximal inhibitory concentration: 19800 nM
For compound 4 the middle estimate is 4.0-fold (0.60 log units) below the measured one, outside the stated range (above it).
By their numbers in this assay, from the lowest: compound 1; then compound 2; then compounds 4 and 3 (each within the scatter of the next).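

In this assay, within the data shown here, this position proves more sensitive than the one earlier step indicated: 3,4-difluorophenyl in place of 3-chlorophenyl gives a 5.4-fold higher number from compound 1 to compound 4 (0.73 log units; beyond the scatter), compared with a 2.3-fold higher number from compound 1 to compound 2 (0.37 log units; beyond the scatter) for the change to 2,4-dichlorophenyl. The same difluorophenyl group also gives a 2.3-fold higher number from compound 2 to compound 4 (0.36 log units; beyond the scatter), so on the shared core the three aryl groups now stand apart, with 3-chlorophenyl lowest and 3,4-difluorophenyl highest. Nothing available explains this order.

Still open is where 3-fluorophenyl and 3,4-dichlorophenyl would stand on the same core, since the compounds shown do not separate the choice of halogen from its placement. Also open, on these data alone, is whether an unsubstituted phenyl, or a phenyl carrying a methoxy group or an amine, would give a number lower than that of compound 1.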